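This account rests on a few compounds, and the source may have more. Where it says the series, first, only, none or still open, it means among the compounds named here.

In an ADME assay (liver) for metabolic stability, with Liver microsome (Rattus norvegicus) as the target, read by LC-MS, using microsomes and NADPH, with stated times of 5 min and 60 min, tested at 4 uM (on this read-out lower numbers stand for a less stable compound and higher numbers for a more stable compound), compound 1 (`Cc1c(OCCCCOc2ccc(C(=O)O)cc2Cl)ccc(C(=O)CC2CCCC2)c1O`) gives 21% and compound 3 (`Cc1c(OCCCCOc2cccc(C(=O)O)c2)ccc(C(=O)CC(C)C)c1C`) gives 29%, two values within the scatter of each other. Compound 2 (`Cc1c(OCCCCOc2ccc(F)c(C(=O)O)c2)ccc(C(=O)CC(C)(C)C)c1O`) gives 58%, beyond the scatter from compound 1. Compound 4 (`COc1ccc(C(=O)O)cc1OCCCCOc1ccc(C(=O)CC2CCCC2)c(O)c1C`) differs from compound 1 in one place: 5-carboxy-2-methoxyphenyl in place of 4-carboxy-2-chlorophenyl on an oxygen on a saturated carbon. Among the compounds with values here, no measured pair isolates this change. With compound 1 at 21% as the anchor, no step beyond the scatter is expected in this assay, and a direction can only be tentative. The estimated step is a number 5 percentage points higher from compound 1 to compound 4 (within the scatter). Compound 4 is estimated at 26%, with an expected range of 10% to 46%.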

Compound 4, percent of the compound remaining: 14%
Compound 4: middle estimate off by 12 percentage points, on the high side; the measured number falls inside the stated range.
By their numbers in this assay, from the lowest: compounds 4, 1 and 3 (each within the scatter of the next, the first and the last beyond it); then compound 2.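

In this assay, within the data shown here, the step of a number 7 percentage points lower from compound 1 to compound 4 (within the scatter) comes with 5-carboxy-2-methoxyphenyl in place of 4-carboxy-2-chlorophenyl on an oxygen on a saturated carbon, the first single-place change that can be read. This exchange of aryl groups therefore does not separate the two compounds on this read-out. No measured information bears on the cause of this result.

The exchange alters both the ring substituent and the carboxy number in the group's name, so neither can be read alone. As far as these compounds go, whether an amide in place of the carboxylic acid would give a step beyond the scatter stays open.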